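This account rests on a few compounds, and the source may have more. Where it says the series, first, only, none or still open, it means among the compounds named here.

Series notes. In an assay on CHO cells for displacement of a labelled ligand from prostaglandin E2 receptor EP1 subtype (Homo sapiens) (a lower number here means a stronger inhibitor, a higher number a weaker inhibitor), compound 1 `COc1ccc(Cc2nnc(CN(c3cccc(Cl)c3C)S(=O)(=O)c3ccc(C)cc3)o2)cc1` gives 6.31 nM; compound 2 `Cc1ccc(S(=O)(=O)N(Cc2nnc(Cc3ccc(C(F)(F)F)cc3)o2)c2cccc(Cl)c2C)cc1` gives 50.1 nM; compound 3 `Cc1ccc(S(=O)(=O)N(Cc2nnc(Cc3cccc(F)c3)o2)c2cccc(Cl)c2C)cc1` gives 316 nM, the highest of the three numbers, with compound 2 the nearest and compound 1 the furthest. Compound 4 `Cc1ccc(S(=O)(=O)N(Cc2nnc(Cc3ccc(Cl)cc3Cl)o2)c2cccc(Cl)c2C)cc1` is not yet measured. Its change from compound 3 is 2,4-dichlorophenyl in place of 3-fluorophenyl on a saturated chain carbon bound to an aromatic carbon; cut one bond further out, the difference reads 3-fluorobenzyl to 2,4-dichlorobenzyl. The measured steps at this place are a 50-fold higher number from compound 1 to compound 3 (1.70 log units; beyond the scatter) and a 6.3-fold higher number from compound 2 to compound 3 (0.80 log units; beyond the scatter), and a 7.9-fold higher number from compound 1 to compound 2 (0.90 log units; beyond the scatter) changes the same group. All three lie beyond the scatter, so this group has moved this assay each time it was varied, and compound 3 holds the weakest end of what has been seen. Among the compounds with values here, no measured compound carries a 2,4-dichlorophenyl, so the direction is taken mainly from compound 2 with its 4-(trifluoromethyl)phenyl at 50.1 nM, and the expectation is that a fuller ring brings compound 4 back toward that number. The expected step is a 4.0-fold lower number from compound 3 to compound 4 (0.60 log units; beyond the scatter). The estimate for compound 4 in this assay is 80 nM, with a range from 25 nM to 300 nM.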

Compound 4, half-maximal inhibitory concentration: 63.1 nM
Beside the measured number, compound 4's estimate is 1.3-fold (0.10 log units) above it; measured number inside the range.
By their numbers in this assay, from the lowest: compound 1; then compounds 2 and 4 (each within the scatter of the next); then compound 3.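

In this assay, the 2,4-dichlorophenyl gives a 5.0-fold lower number from compound 3 to compound 4 (0.70 log units; beyond the scatter), so the weak end held by the 3-fluorophenyl is not a general limit on rings at this place. Two different rings now sit level, with a 1.3-fold higher number from compound 2 to compound 4 (0.10 log units; within the scatter), while the 4-methoxyphenyl keeps its lead over the 2,4-dichlorophenyl, with a 10-fold higher number from compound 1 to compound 4 (1.00 log units; beyond the scatter). No measured data bear on why these rings separate in this way.

The compounds shown do not settle whether both chlorines of compound 4 are needed, which a ring with a single chlorine would address. They also leave open whether the lead of compound 1 is specific to methoxy or extends to an ethoxy group, and how a carboxylic acid on this ring would read.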